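Removing the acyl group from an aromatic amine

The source may hold more compounds than are shown below. What is called first, only, known or untested is meant among the compounds shown, and "the series" means these compounds.

Compound 1 `CCS(=O)(=O)Nc1cccc2c1CCCC2c1c[nH]cn1` gives 631 nM in an assay on isolated protein for agonist activity at Alpha-1A adrenergic receptor (Oryctolagus cuniculus); a higher number here means that more compound is needed for the effect, a lower number that less compound is needed. Going by the values given here, compound 2 `CC(=O)Nc1cccc2c1CCCC2c1c[nH]cn1` gives 1290 nM in this assay, the highest of the two numbers; the only measured step, a 2.0-fold higher number from compound 1 to compound 2 (0.31 log units; beyond the scatter), is modest. Compound 3 `Nc1cccc2c1CCCC2c1c[nH]cn1` carries hydrogen in place of acetyl on a nitrogen on an aromatic ring. Among the compounds with values here, no measured step removes the acyl group altogether, so the direction of the acyl swap is the only guidance, and it is weak. Compound 3 is therefore expected to give about 3000 nM, within 800 nM to 12000 nM. This estimate means a step of a 2.3-fold higher number from compound 2 to compound 3 (0.37 log units; beyond the scatter), expected to exceed the scatter but with wide uncertainty.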

Compound 3, half-maximal effective concentration: 275 nM
The estimate for compound 3 lay 11-fold (1.04 log units) above the measured number, and the stated range ends above it.
By their numbers in this assay, from the lowest: compound 3; then compound 1; then compound 2.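

In this assay the acyl group on the nitrogen on the aromatic ring proves dispensable: hydrogen in place of acetyl lowers the number (a 4.7-fold lower number from compound 2 to compound 3 (0.67 log units; beyond the scatter)), and hydrogen in place of ethylsulfonyl does too (a 2.3-fold lower number from compound 1 to compound 3 (0.36 log units; beyond the scatter)). Among these three compounds, the unsubstituted amino group therefore gives the lowest number, and neither acetyl nor ethylsulfonyl is required at this position. Nothing available explains why this is so.

Still open, going by these compounds, is how a single methyl on this nitrogen, or a urea there, would compare with the free amino group. On these data alone, it is also open whether a longer alkyl chain would raise the number again.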